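This account rests on a few compounds, and the source may have more. Where it says the series, first, only, none or still open, it means among the compounds named here.

Measured in a functional assay on Raji cells (Homo sapiens) for cytotoxicity, with a stated time of 72 h; on this read-out higher numbers stand for an effect only at larger amounts of compound and lower numbers for an effect already at smaller amounts:
- compound 1 `C=C[C@@](C)(/C=C/c1ccc(OS(=O)(=O)c2ccc(C)cc2)cc1)CCC=C(C)C`: > 26000 nM
- compound 2 `C=C[C@@](C)(/C=C/c1ccc(O)cc1)CCC1OC1(C)C`: > 22500 nM
- compound 3 `C=C[C@@](C)(/C=C/c1ccc(O)cc1)CC/C=C/C(=O)OCc1ccccc1`: > 26000 nM

Compound 2 gives > 22500 nM, which is a limit and not a number. The other two entries are limits as well, so compound 2 has no rank against compound 1 or compound 3.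

The next compound is compound 4 `C=C[C@@](C)(/C=C/c1ccc(O)cc1)CC/C=C(\C)C=O`. In it, 2-formylprop-1-en-1-yl stands in place of 3,3-dimethyloxiran-2-yl on a saturated chain carbon, three bonds along the chain from two double-bonded chain carbons: 2-formylprop-1-en-1-yl in place of 3,3-dimethyloxiran-2-yl on a saturated chain carbon, three bonds along the chain from two double-bonded chain carbons.

Within the data shown here, no measured step between compounds differing in one place is available to size this change. With no number anywhere in the series, no step beyond the scatter is expected. The expected step is an at least 1.0-fold lower number from compound 2 to compound 4 (0.00 log units; that floor lies within the scatter). A further limit is the most likely report for compound 4. If a number does appear, the estimate for compound 4 is 22000 nM, with an expected range from 9000 nM to 40000 nM.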

Compound 4, half-maximal effective concentration: > 26000 nM
Compound 4 gave a limit, no number; the forecaster's own chance of this, stated with the estimate: 70%; middle value at least 1.1-fold (0.07 log units) away from the limit.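

Compound 2 gives > 22500 nM, a limit. Compound 4 gives > 26000 nM, also a limit. Among these compounds, no step from compound 2 to compound 4 can be read from these two limits. The compounds shown leave open what size of effect, if any, 2-formylprop-1-en-1-yl has in place of 3,3-dimethyloxiran-2-yl.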